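A few compounds are considered here, and "the series" means these few. Any claim that something is new, unique, unknown or untested is made for them only; others in the source may bear on it.

Measured in an ADME assay on Vero cells (Chlorocebus sabaeus) for cytotoxicity, read by MTT assay, with a stated time of 72 h; a higher number here means that more compound is tolerated, a lower number that less compound is tolerated:

Compound 1 `O=C(c1ccccc1F)N1CCN(c2nc(=O)c3cc(C(F)(F)F)cc([N+](=O)[O-])c3s2)CC1` gives > 125000 nM, a limit.
Compound 2 `CC(=O)N1CCN(c2nc(=O)c3cc(C(F)(F)F)cc([N+](=O)[O-])c3s2)CC1` gives > 125000 nM, a limit.
Compound 3 `O=c1nc(N2CCN(CC3CCCCC3)CC2)sc2c([N+](=O)[O-])cc(C(F)(F)F)cc12` gives > 125000 nM, a limit.

Compound 2 stands at the limit, as the whole set does: the limit of > 125000 nM in this assay, at which 3 of the 3 values shown sit. The steps touching compound 2, a step that the two limits leave unreadable from compound 1 to compound 2 and a step that the two limits leave unreadable from compound 2 to compound 3, are therefore unreadable, as is a step that the two limits leave unreadable from compound 1 to compound 3. Compound 4 `CCCC(=O)N1CCN(c2nc(=O)c3cc(C(F)(F)F)cc([N+](=O)[O-])c3s2)CC1` differs from compound 2 by ethyl in place of hydrogen on a saturated chain carbon bound to a carbonyl carbon. Among the measured compounds shown here, no measured step gives a readable size, so the only basis for compound 4 is that every neighbour sits at the limit. In this assay the expected step is a step that the limit leaves unreadable from compound 2 to compound 4, that is none that could be read, with compound 4 most likely reported again as a limit. The estimate for compound 4 is 150000 nM, expected to lie between 60000 nM and 500000 nM.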

Compound 4, half-maximal cytotoxic concentration: > 125000 nM
Compound 4 was reported as a limit; the forecaster's own chance of this, stated with the estimate: 85%; the middle value is on the limit's open side.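

In this assay, among the compounds shown here, compound 4 gives > 125000 nM, a limit, so no step between compound 4 and compound 1, compound 2 or compound 3 can be read. The compounds shown leave open what concentration of any of them would no longer be tolerated.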